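A few compounds are considered here, and "the series" means these few. Any claim that something is new, unique, unknown or untested is made for them only; others in the source may bear on it.

Measured compounds in an assay for inhibition of kynurenine 3-monooxygenase (Homo sapiens), read by mass spectrometry, with a stated time of 1 h; a lower number here means a stronger inhibitor, a higher number a weaker inhibitor:
compound 1 `CC(C)Cc1cc2oc(=O)n(CCC(=O)O)c2cc1Cl` gives 12.6 nM
compound 2 `O=C(O)CCn1c(=O)oc2cc(OCc3ccccn3)c(Cl)cc21` gives 3.16 nM
compound 3 `CCOc1cc2oc(=O)n(CCC(=O)O)c2cc1Cl` gives 5.01 nM

Compound 3 holds the second highest number of the three. Its gap to compound 2 is within the scatter, a 1.6-fold higher number from compound 2 to compound 3 (0.20 log units; within the scatter), whereas the step from compound 1 is beyond it, a 2.5-fold lower number from compound 1 to compound 3 (0.40 log units; beyond the scatter).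

Compound 4 `O=C(O)CCn1c(=O)oc2cc(OCC3CC3)c(Cl)cc21` differs from compound 3 in one place: cyclopropyl in place of methyl on a saturated chain carbon bound to an oxygen on an aromatic ring

Among the compounds with values here, the only measured step at the same place is a 1.6-fold higher number from compound 2 to compound 3 (0.20 log units; within the scatter), a gap within the scatter. The steps on the aromatic carbon, a 4.0-fold lower number from compound 1 to compound 2 (0.60 log units; beyond the scatter) and a 2.5-fold lower number from compound 1 to compound 3 (0.40 log units; beyond the scatter), show both ethoxy and (pyridin-2-yl)methoxy giving lower numbers than isobutyl. No step beyond the scatter is therefore expected in this assay, a 1.3-fold lower number from compound 3 to compound 4 (0.10 log units; within the scatter). For compound 4 the estimate is 4 nM, range 1.5 nM to 12 nM.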

Compound 4, half-maximal inhibitory concentration in the kynurenine 3-monooxygenase assay: 10 nM
The estimate for compound 4 lay 2.5-fold (0.40 log units) below the measured number; measured number inside the range.
By their numbers in the kynurenine 3-monooxygenase assay, from the lowest: compounds 2, 3, 4 and 1 (each within the scatter of the next, the first and the last beyond it).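

In the kynurenine 3-monooxygenase assay, cyclopropylmethoxy stays within the scatter of ethoxy (a 2.0-fold higher number from compound 3 to compound 4 (0.30 log units; within the scatter)) and of isobutyl (a 1.3-fold lower number from compound 1 to compound 4 (0.10 log units; within the scatter)), whereas the pyridin-2-yl group gives a lower number than cyclopropyl at this place (a 3.2-fold higher number from compound 2 to compound 4 (0.50 log units; beyond the scatter)). In a physicochemical assay for pharmacokinetics, at pH 6 (a higher number here means that the compound lasts longer, a lower number that the compound disappears faster), compound 3 gives > 1000 h, which is a limit of the assay. In the physicochemical assay compound 4 gives > 1000 h, again a limit, so the step between the two cannot be read: the limit of > 1000 h in the physicochemical assay, at which 2 of the 2 values shown sit.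

Open, going by these compounds, is how an amine or a phenyl ring in place of cyclopropyl on the saturated chain carbon would stand in the kynurenine 3-monooxygenase assay.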